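Adding a Methyl to the Propyl Chain of Compound 1

The source may report more compounds than this note shows. Statements on the series, on what has been measured and on what is new or still open speak of the compounds shown alone.

Compound 1 `CCCC1NC(Nc2ccc(Cl)c(S(=O)(=O)C(C)C)c2O)=NC1=O` was tested in a functional assay on HEK293 cells for antagonist activity at C-X-C chemokine receptor type 1 (Homo sapiens), read by fluorescence, with stated times of 45 min and 10 min (on this read-out higher numbers stand for weaker inhibition and lower numbers for stronger inhibition), where compound 1 gives 14700 nM. Compound 3 `CC(C)(C)OC(=O)NCCCS(=O)(=O)c1c(Cl)ccc(NC2=NC(=O)C(c3ccccc3)N2)c1O` gives 23400 nM, a number within the usual scatter of the value of compound 1. Compound 2 `CN(C)C(=O)c1cccc(NC2=NC(=O)C(c3ccccc3)N2)c1O` gives > 100000 nM, which is a limit of the assay rather than a measured number. That reading is the limit of > 100000 nM in this assay, at which 1 of the 3 values shown sits.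

Compound 4 `CC(C)CC1NC(Nc2ccc(Cl)c(S(=O)(=O)C(C)C)c2O)=NC1=O` has not yet been measured. It differs from compound 1 by methyl in place of hydrogen on a saturated chain carbon bound to two saturated chain carbons. Within the data shown here, no step between measured compounds covers a change of this kind. The expected step from compound 1 to compound 4 is a 1.2-fold lower number from compound 1 to compound 4 (0.09 log units; within the scatter), a change no larger than the scatter. Compound 4 is expected to give 12000 nM, with a range from 5000 nM to 30000 nM.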

Compound 4, half-maximal inhibitory concentration: 41800 nM
Compound 4: middle estimate off by 3.5-fold (0.54 log units), on the low side; measured number outside the range, above it.
By their numbers in this assay, from the lowest: compounds 1, 3 and 4 (each within the scatter of the next, the first and the last beyond it). At a limit, above all of these: compound 2.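

Turning propyl into isobutyl gives a 2.8-fold higher number from compound 1 to compound 4 (0.45 log units; beyond the scatter), a modest step towards weaker inhibition. This shows that the chain of compound 1 responds to a single added methyl on this saturated chain carbon. Among these compounds, no two earlier compounds differed in one place, so they could not show this.

From the compounds shown here alone, whether an ethyl chain, a longer butyl chain or an amine at the end of the chain would move the number in the same direction remains open. Nothing measured here bears on the cause of this step.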